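A few compounds are considered here, and "the series" means these few. Any claim that something is new, unique, unknown or untested is made for them only; others in the source may bear on it.

Compound 2 `COc1ccc([C@H]2CC(=O)N(c3cccc(NS(=O)(=O)c4cc(C)ccc4OC)c3)C2)cc1OC1CCCC1` is the sulfonamide of the series. In a functional assay on HEK293 cells (Homo sapiens) for cytotoxicity (on this read-out higher numbers stand for lower toxicity in this test and lower numbers for higher toxicity in this test), compound 2 gives > 10000 nM, which is a limit of the assay and not a number. Among the compounds with values here, its only measured neighbour is compound 1 `COc1ccc([C@H]2CC(=O)N(c3cccc(NC(=O)C(C)=O)c3)C2)cc1OC1CCCC1`, in which an acetylcarbonyl sits on the nitrogen on the aromatic ring in place of the (2-methoxy-5-methylphenyl)sulfonyl. In this assay compound 1 gives > 10000 nM, again a limit. The step that the two limits leave unreadable from compound 1 to compound 2 is therefore of unreadable size, and the whole picture so far is the limit of > 10000 nM in this assay, at which 2 of the 2 values shown sit.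

Compound 3 `COc1ccc([C@H]2CC(=O)N(c3cccc(NS(=O)(=O)c4ccccc4C)c3)C2)cc1OC1CCCC1` is the next variation on the sulfonyl end: 2-methylphenyl in place of 2-methoxy-5-methylphenyl on a sulfonyl sulfur. Within the data shown here, no measured step bears readably on this change, since the exchange of the whole group at this nitrogen between compound 1 and compound 2 left both values at the limit. The expectation is that compound 3 also stays at or past the limit, so the step that the limit leaves unreadable from compound 2 to compound 3 is expected to be nothing beyond the scatter. For compound 3 in this assay the estimate is 20000 nM, with a range from 8000 nM to 60000 nM, most probably reported only as a limit.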

Compound 3, half-maximal cytotoxic concentration: > 10000 nM
Compound 3 was reported as a limit (the forecaster's own chance of this, stated with the estimate: 80%); the middle value lies beyond the limit too.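

In this assay compound 3 gives > 10000 nM as a limit of the assay and not a number. The steps among compound 1, compound 2 and compound 3 therefore cannot be read, and the series stands as follows: the limit of > 10000 nM in this assay, at which 3 of the 3 values shown sit. The compounds shown leave open at what concentration any of them becomes cytotoxic, and whether the groups at the nitrogen differ at all.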